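The compounds below may be only part of what the source reports. "The series", "measured", "known", "first", "only" and "open" are said of these compounds alone.

Measured compounds:
- compound 1, `Cc1c(Cc2ccccc2)c(NNC(=O)Nc2cc(Cl)nc(Cl)c2)nc2c1cnn2C`, in a functional assay on HCT-116 cells (Homo sapiens) for cytotoxicity, read by MTT assay, with a stated time of 48 h, in the presence of a further agent that is not named here (on this read-out higher numbers stand for an effect only at larger amounts of compound and lower numbers for an effect already at smaller amounts), compound 1 gives 13600 nM
- compound 2, `CCN(CC)c1cc(NC(=O)NNc2cc(-c3ccc(F)cc3)c3cnn(C)c3n2)cc(Cl)n1`, in this assay compound 2 gives 29400 nM
- compound 3, `Cn1nc(C(F)(F)F)c2c(-c3ccccc3)cc(NNC(=O)Nc3cc(Cl)nc(Cl)c3)nc21`, in this assay compound 3 gives 18100 nM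

All three compounds share a core carrying a hydrazine-linked urea, and their three numbers lie close together. Compound 3 stands in the middle of the three: compound 1 is nearest to it and compound 2 furthest, and both gaps are within the usual scatter of repeated measurements, so the three numbers cannot be told apart with confidence.

Compound 4, `Cc1nn(C)c2nc(NNC(=O)Nc3cc(Cl)nc(Cl)c3)cc(-c3ccccc3)c12`, has not been measured yet. It differs from compound 3 in a single place:

methyl in place of trifluoromethyl on an aromatic carbon

For the measured compounds named here, no pair of measured compounds differs by this change alone, so there is no measured step to lean on. The three measured numbers sit within the scatter of one another despite larger differences in their substituents, which gives no reason to expect this smaller change to move the number far. The step from compound 3 to compound 4 in this assay is therefore estimated as a 1.1-fold lower number from compound 3 to compound 4 (0.03 log units; within the scatter), nothing beyond the scatter. For compound 4 in this assay the expected value is 17000 nM, with a range from 6000 nM to 45000 nM.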

Compound 4, half-maximal effective concentration: 80000 nM
Compound 4: middle estimate off by 4.7-fold (0.67 log units), on the low side; the measured number lies above the stated range.
By their numbers in this assay, from the lowest: compounds 1, 3 and 2 (each within the scatter of the next, the first and the last beyond it); then compound 4.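

In this assay the change from trifluoromethyl to methyl gives a 4.4-fold higher number from compound 3 to compound 4 (0.65 log units; beyond the scatter) and is the only single-place step shown here, so this is the first direct sign that the group at this position matters. The earlier compounds shown here could not show this, as they differ from one another in more than one place. Here, methyl needs a larger amount of compound for the same effect than trifluoromethyl does, yet nothing measured here explains the step.

The compounds shown leave open how hydrogen, chlorine, an ethyl group or a nitrile would behave on this aromatic carbon. They also leave open whether the step would keep its size with a benzyl group or a 4-fluorophenyl group elsewhere on the shared core.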